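Gem-dimethyl Branching at the Side Chain of Compound 1

The source may report more compounds than this note shows. Statements on the series, on what has been measured and on what is new or still open speak of the compounds shown alone.

Measured compounds:
compound 1, `CC(=O)CC1CC(=O)N(c2ccccc2)C1=O`, 62400 nM
compound 2, `Cc1ccc(C(=O)CC2CC(=O)N(c3ccc(S(N)(=O)=O)cc3)C2=O)cc1`, 860 nM
compound 3, `NS(=O)(=O)c1ccc(N2C(=O)CC(C3CCCCCC3=O)C2=O)cc1`, 16200 nM

Of the compounds shown here, three share a five-membered imide core and have been tested in an assay on cells (1-87 tumor cell line) for inhibition of Polyunsaturated fatty acid 5-lipoxygenase (Homo sapiens), with a stated time of 5 min; a lower number here means a stronger inhibitor, a higher number a weaker inhibitor. Compound 1 gives 62400 nM, the highest number of the three, and both of its gaps to the other two lie beyond the scatter, so it is the weakest inhibitor here. Compound 3, with 16200 nM, stands nearest to it; compound 2, with 860 nM, stands furthest away.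

The next compound, compound 4, `CC(=O)C(C)(C)C1CC(=O)N(c2ccccc2)C1=O`, follows from compound 1 by one change: 1-acetyl-1-methylethyl in place of 2-oxopropyl on a saturated ring carbon. The side chain thus keeps its single carbonyl and gains two carbons, with no ring formed and no change in donors, acceptors or charge.

Going by the values given here, no pair of measured compounds differs in only this place, so there is no measured step to lean on. The change is small and confined to the side chain, and the expectation is for no shift beyond the scatter in this assay. The estimated step from compound 1 to compound 4 is a 1.2-fold lower number from compound 1 to compound 4 (0.10 log units; within the scatter). Compound 4 is expected to give about 50000 nM, within a range of 15000 nM to 160000 nM.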

Compound 4, half-maximal inhibitory concentration: 53500 nM
Beside the measured number, compound 4's estimate is 1.1-fold (0.03 log units) below it; measured number inside the range.
By their numbers in this assay, from the lowest: compound 2; then compound 3; then compounds 4 and 1 (each within the scatter of the next).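

In this assay, going by these compounds alone, putting 1-acetyl-1-methylethyl in place of 2-oxopropyl on the saturated ring carbon gives a 1.2-fold lower number from compound 1 to compound 4 (0.07 log units; within the scatter), and this is the first step that can be read at a single place. The earlier compounds shown here differ from one another in more than one place, so they could not show that this position accepts a group of 6 heavy atoms in place of one of 4, with the single carbonyl kept, without a shift beyond the scatter. Nothing available here accounts for this result.

As far as these compounds go, it remains open whether the number would also hold if the carbonyl of this side chain gave way to a carboxylic acid or an amine, or if a longer chain stood at this position. Within the data shown here, it is equally open whether 1-acetyl-1-methylethyl would give a step of similar size on a core with a sulfonamide, such as that of compound 2, since the only step read so far belongs to the core of compound 1.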